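The source may report more compounds than this note shows. Statements on the series, on what has been measured and on what is new or still open speak of the compounds shown alone.

compound 1 `CS(=O)(=O)Oc1c(C(=O)NCc2ccc(F)cc2)nc(Br)c2cccnc12` — > 20000 nM
compound 2 `O=CNCCCCCCNc1nc(C(=O)NCc2ccc(F)cc2)c(O)c2ncccc12` — 4000 nM
compound 3 `N[C@H]1CC[C@H](Nc2c(C(=O)NCc3ccc(F)cc3)nc(N3CCCCS3(=O)=O)c3cccnc23)CC1` — > 10000 nM

All three were tested in a functional assay on HCT-116 cells (Homo sapiens) for cytotoxicity, read by MTT assay, with a stated time of 72 h; on this read-out higher numbers stand for weaker inhibition and lower numbers for stronger inhibition. For compound 1 the value > 20000 nM is a limit of the assay, not a number, so compound 1 stands at the limit of > 20000 nM in this assay, at which 1 of the 3 values shown sits, rather than on a measured figure. For compound 3 the value > 10000 nM is also a limit, at the limit of > 10000 nM in this assay, at which 1 of the 3 values shown sits. Compound 2 alone gives a real number, 4000 nM. Compound 4 `O=C(NCc1ccc(F)cc1)c1nc(Br)c2cccnc2c1NCCO` has not yet been measured. It differs from compound 1 in a single change: (2-hydroxyethyl)amino in place of (methylsulfonyl)oxy on an aromatic carbon. Compound 1 sits at a limit, so the step from it can only be judged loosely. The step is expected to be an at least 2.5-fold lower number from compound 1 to compound 4 (0.39 log units; beyond the scatter), a modest gain at most, though a value within the scatter or another limit is possible. The estimate for compound 4 is 8000 nM, between 2000 nM and 30000 nM.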

Compound 4, half-maximal inhibitory concentration: > 20000 nM
Compound 4: only a limit was reported; the forecaster's own chance of this, stated with the estimate: 40%; middle value at least 2.5-fold (0.39 log units) away from the limit.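

For the compounds shown here, compound 1 and compound 4 both give only a limit in this assay, so no step between them can be read: the limit of > 20000 nM in this assay, at which 2 of the 4 values shown sit. As far as these compounds go, whether (2-hydroxyethyl)amino in place of (methylsulfonyl)oxy changes the cytotoxicity at all stays open.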